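Formyl to hydroxymethyl on the fluoro compound

The compounds below may be only part of what the source reports. "The series", "measured", "known", "first", "only" and "open" are said of these compounds alone.

Within the data shown here, in a functional assay on NCI-H460 cells (Homo sapiens) for cytotoxicity, read by sulforhodamine B assay, with a stated time of 3 days (on this read-out higher numbers stand for weaker inhibition and lower numbers for stronger inhibition), compound 1 `O=Cc1cn(Cc2ccc(Cl)cc2)c2cc(F)ccc12` gives 120 nM and compound 2 `O=Cc1cn(Cc2ccc(Cl)cc2)c2cc(Br)ccc12` gives 90 nM, so compound 1 stands level with its only measured neighbour. Compound 3 `OCc1cn(Cc2ccc(Cl)cc2)c2cc(F)ccc12` keeps the fluoro group of compound 1 and differs elsewhere: hydroxymethyl in place of formyl on an aromatic carbon. This is hydroxymethyl in place of formyl on an aromatic carbon.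

Among the measured compounds shown here, the one measured step, a 1.3-fold lower number from compound 1 to compound 2 (0.12 log units; within the scatter), is bromo in place of fluoro. It lies at a different place and sets no size for the present change. For the measured compounds named here, no measured step touches the formyl group, so the expectation is loose. A move to a higher number in this assay is expected, with the expected step being a 3.3-fold higher number from compound 1 to compound 3 (0.52 log units; beyond the scatter). For compound 3 the estimated value is 400 nM, with an expected range of 90 nM to 2500 nM.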

Compound 3, half-maximal inhibitory concentration: 450 nM
Compound 3: the middle estimate sits 1.1-fold (0.05 log units) below what was measured; low and high end bracket the measured number.
By their numbers in this assay, from the lowest: compounds 2 and 1 (each within the scatter of the next); then compound 3.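

In this assay, among these compounds, this carbon, two ring bonds from the ring nitrogen, is the first place where a single change gives a step beyond the scatter (a 3.8-fold higher number from compound 1 to compound 3 (0.57 log units; beyond the scatter)). The step is modest, and on this pair the formyl group gives the lower number. The change removes the double bond outside aromatic rings and brings in a hydrogen-bond donor, but no measurement available here separates these two differences or otherwise accounts for the step.

As far as these compounds go, whether the step carries over from the fluoro compound to the bromo compound 2 remains open. Also open, from the compounds shown here alone, is how a carboxylic acid, a nitrile or an aminomethyl group on this carbon would compare with formyl and hydroxymethyl.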